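Replacing the ethyl of compound 2 with cyclohexyl

The source may report more compounds than this note shows. Statements on the series, on what has been measured and on what is new or still open speak of the compounds shown alone.

Compound 2 `CCc1ccc(NS(=O)(=O)c2ccc(N3CCNC3=O)cc2)cc1` gives 480 nM in a functional assay on M21 cells (Homo sapiens) for antiproliferative activity, read by sulforhodamine B assay, with a stated time of 48 h; on this read-out higher numbers stand for weaker inhibition and lower numbers for stronger inhibition. Among the three measured compounds it stands highest: compound 1 `O=C1NCCN1c1ccc(S(=O)(=O)Nc2cccc(Br)c2)cc1` gives 59 nM, and compound 3 `Cc1ccccc1NS(=O)(=O)c1ccc(N2CCNC2=O)cc1` gives 150 nM. The step of an 8.1-fold higher number from compound 1 to compound 2 (0.91 log units; beyond the scatter) is the largest in the set, while a 2.5-fold higher number from compound 1 to compound 3 (0.41 log units; beyond the scatter) and a 3.2-fold lower number from compound 2 to compound 3 (0.51 log units; beyond the scatter) are both smaller.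

Compound 4 `O=C1NCCN1c1ccc(S(=O)(=O)Nc2ccc(C3CCCCC3)cc2)cc1` is not yet measured. It differs from compound 2 in one place: cyclohexyl in place of ethyl on an aromatic carbon.

Going by the values given here, none of the measured steps touches this change. All three steps swap one aryl group for another on the sulfonamide nitrogen; none of them enlarges a group already present on an aromatic carbon of that ring. Among the compounds with values here, the only guidance is that compound 2, the one carrying the ethyl, already gives the weakest number of the three, so the shared core tolerates a substituent at this place, but how it responds to a much larger one cannot be read from the data.

On that basis compound 4 is expected to stay near compound 2, with a step of a 1.1-fold higher number from compound 2 to compound 4 (0.06 log units; within the scatter) that is not expected to go beyond the scatter in either direction. The estimate for compound 4 is 550 nM, within a range from 130 nM to 2300 nM.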

Compound 4, half-maximal inhibitory concentration: > 1000 nM
Compound 4 was reported as a limit; the forecaster's own chance of this, stated with the estimate: 5%; middle value at least 1.8-fold (0.25 log units) away from the limit.
By their numbers in this assay, from the lowest: compound 1; then compound 3; then compound 2. At a limit, above all of these: compound 4.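

In this assay compound 4 is reported only as a limit, > 1000 nM. Placing cyclohexyl in place of ethyl on the aromatic carbon para to a large group gives an at least 2.0-fold higher number from compound 2 to compound 4 (0.31 log units; beyond the scatter), so this position does not accept the larger carbon ring without a move toward weaker inhibition, something the earlier steps could not show, as each of them exchanged one whole aryl group for another on the sulfonamide nitrogen. The size of this change remains bounded on one side only, and how far compound 4 really stands from compound 2 cannot be told: the limit of > 1000 nM in this assay, at which 1 of the 4 values shown sits.

With only ethyl and cyclohexyl shown at this place, the compounds leave open whether the rise in the number follows the growing count of carbon atoms or the presence of a ring, which a straight butyl or hexyl chain there would separate. They also leave open how this position would respond to a group of a different kind, such as an amine, a carboxylic acid or a methoxy group, or to a bare hydrogen in place of the ethyl.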